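Compound 4 and a swap of methoxycarbonyl for methoxy

A few compounds are considered here, and "the series" means these few. Any claim that something is new, unique, unknown or untested is made for them only; others in the source may bear on it.

compound 1 `O=S1(=O)C=C(Sc2nnc(C3CCCCC3)o2)c2ccccc21` gives 15000 nM
compound 2 `COc1ccccc1-c1nnc(SC2=CS(=O)(=O)c3ccccc32)o1` gives 16000 nM
compound 3 `COC(=O)c1ccc(-c2nnc(SC3=CS(=O)(=O)c4ccccc43)o2)cc1` gives 18000 nM

All three values come from an ADME assay on HepG2 cells (Homo sapiens) for cytotoxicity, read by fluorescence and resazurin assay, with a stated time of 24 h (on this read-out higher numbers stand for lower toxicity in this test and lower numbers for higher toxicity in this test), and compound 3 at 18000 nM lies within the scatter of both compound 1 and compound 2, so its place among them carries no order. Compound 4 `COc1ccc(-c2nnc(SC3=CS(=O)(=O)c4ccccc43)o2)cc1` has not yet been measured. It differs from compound 3 in one place, on an aromatic carbon of a six-membered aromatic ring of carbon only, para to a large group, where methoxy stands in place of methoxycarbonyl (methoxy in place of methoxycarbonyl on an aromatic carbon). For the measured compounds named here, the only measured step is a 1.1-fold higher number from compound 1 to compound 2 (0.03 log units; within the scatter) and it puts 2-methoxyphenyl in place of cyclohexyl, so it stays within the scatter despite a large exchange of groups. Going by the values given here, no measured step exchanges methoxycarbonyl for methoxy directly. Compound 2 at 16000 nM already carries a methoxy-bearing aryl group and compound 3 at 18000 nM a methoxycarbonyl-bearing one, and these two values lie within the scatter of each other. The expected step is a 1.1-fold lower number from compound 3 to compound 4 (0.05 log units; within the scatter) and it is estimated to stay within the scatter, with no direction foreseen. For compound 4 the estimate is 16000 nM with an expected range from 8000 nM to 32000 nM when measured.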

Compound 4, half-maximal cytotoxic concentration: 22000 nM
The estimate for compound 4 lay 1.4-fold (0.14 log units) below the measured number; measured number inside the range.
By their numbers in this assay, from the lowest: compounds 1, 2, 3 and 4 (each within the scatter of the next).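

In this assay, for the compounds shown here, methoxy in place of methoxycarbonyl on an aromatic carbon of a six-membered aromatic ring of carbon only, para to a large group, gives a 1.2-fold higher number from compound 3 to compound 4 (0.09 log units; within the scatter) and so offers the first direct exchange of these two groups at this position, which takes either one without leaving the scatter. Compound 4 also extends the picture beyond this position: 4-methoxyphenyl in place of 2-methoxyphenyl gives a 1.4-fold higher number from compound 2 to compound 4 (0.14 log units; within the scatter) and 4-methoxyphenyl in place of cyclohexyl gives a 1.5-fold higher number from compound 1 to compound 4 (0.17 log units; within the scatter) and neither exchange leaves the scatter, so no group tried here separates the compounds in this test. Nothing available explains why these numbers lie so close together.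

From the compounds shown here alone, it remains open whether an amine, a carboxylic acid or a longer chain on this aromatic carbon would give a number beyond the scatter of compound 4. The compounds shown also leave open how far the numbers depend on the shared core, which is the same in all four.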